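A Phenyl Group in Place of the Heptyl Chain

The compounds below may be only part of what the source reports. "The series", "measured", "known", "first", "only" and "open" are said of these compounds alone.

Compound 1 `Cc1[nH]c(=O)n(C)c1-c1ccccc1`: > 100000 nM
Compound 2 `CCCCCCCc1ccc(-c2c(C)[nH]c(=O)n2C)cc1`: 8400 nM

Both compounds were tested in a functional assay on brain (Rattus norvegicus, strain Wistar) for inhibition; a lower number here means a stronger inhibitor, a higher number a weaker inhibitor. The reading for compound 1 of > 100000 nM is a limit and not a number. Among the measured compounds shown here, compound 2 therefore holds the only true number so far, 8400 nM, and there is no wider series to place it in.

The next compound is compound 3 `Cc1[nH]c(=O)n(C)c1-c1ccc(-c2ccccc2)cc1`, with phenyl in place of heptyl on an aromatic carbon. For the measured compounds named here, one measured step bears on this place, and it is large: an at least 11-fold lower number from compound 1 to compound 2 (1.07 log units; beyond the scatter). Compound 3 keeps a group at this carbon, so it is expected to retain part of the gain seen in that step. Going by the values given here, no measured step compares a ring with a chain here, so the expectation is loose. In this assay, a modest shift toward a higher number, meaning weaker inhibition, seems most likely. The expected change is a 3.0-fold higher number from compound 2 to compound 3 (0.47 log units; beyond the scatter). Compound 3 is estimated at 25000 nM, with an expected range from 7000 nM to 90000 nM.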

Compound 3, half-maximal inhibitory concentration: 6300 nM
Beside the measured number, compound 3's estimate is 4.0-fold (0.60 log units) above it; the measured number lies below the stated range.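

In this assay, phenyl in place of heptyl gives a 1.3-fold lower number from compound 2 to compound 3 (0.12 log units; within the scatter), so at this aromatic carbon a six-membered aromatic ring of carbon only and an open chain read alike. The gain over hydrogen is therefore no longer tied to heptyl alone: phenyl in place of hydrogen gives an at least 15-fold lower number from compound 1 to compound 3 (1.20 log units; beyond the scatter), a large step in the same direction as an at least 11-fold lower number from compound 1 to compound 2 (1.07 log units; beyond the scatter), and in the three compounds shown a carbon group at this place goes with the lower number, with none going against it. The reading for compound 1, which anchors both of these steps, is a limit and not a number: the limit of > 100000 nM in this assay, at which 1 of the 3 values shown sits.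

The compounds shown leave open how small a group at this carbon can be while keeping the gain, as a methyl or a propyl chain would show, and whether a group need consist of carbon alone, as an amine or a carboxylic acid would show. They also leave open whether a longer chain, or a second ring set further out, would move the number beyond the scatter.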